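A few compounds are considered here, and "the series" means these few. Any claim that something is new, unique, unknown or untested is made for them only; others in the source may bear on it.

Measured compounds:
Compound 1 `O=C1C[C@H](OCc2cc(-c3ccc([N+](=O)[O-])cc3)no2)[C@H]2CO[C@@H]1O2`: 11200 nM
Compound 2 `O=C1C[C@H](OCc2cc(/C=C/c3ccccc3)no2)[C@H]2CO[C@@H]1O2`: 7100 nM
Compound 3 `O=C1C[C@H](OCc2cc(-c3ccc(Cl)cc3)no2)[C@H]2CO[C@@H]1O2`: 9000 nM

All three share a common core and differ only in the group carried on the five-membered aromatic ring with one nitrogen and one oxygen. In a functional assay on NCI-H1299 cells (Homo sapiens) for cytotoxicity, read by MTT assay, with a stated time of 48 h (on this read-out higher numbers stand for weaker inhibition and lower numbers for stronger inhibition), compound 3 sits among its two neighbours with a number that lies within the scatter of both: the step of a 1.2-fold lower number from compound 1 to compound 3 (0.09 log units; within the scatter) and the step of a 1.3-fold higher number from compound 2 to compound 3 (0.10 log units; within the scatter) are each too small to count as a real difference. On these numbers the three groups tried so far are indistinguishable.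

Compound 4 `O=C1C[C@H](OCc2cc(-c3ccc(Cl)o3)no2)[C@H]2CO[C@@H]1O2` continues this series with the change (5-chlorofuran-2-yl in place of 4-chlorophenyl on an aromatic carbon). Both measured steps bear on it, since each also swaps the group at this carbon, and both stayed within the scatter. There is therefore no ground to expect a step beyond the scatter for compound 4, and its step from compound 3 is estimated as no change at the digits printed from compound 3 to compound 4 (within the scatter). In this assay compound 4 is expected to give about 9000 nM, with a likely range from 4000 nM to 20000 nM.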

Compound 4, half-maximal inhibitory concentration: 7600 nM
Beside the measured number, compound 4's estimate is 1.2-fold (0.07 log units) above it, within the range that was stated.
By their numbers in this assay, from the lowest: compounds 2, 4, 3 and 1 (each within the scatter of the next).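

Setting 5-chlorofuran-2-yl in place of 4-chlorophenyl exchanges a six-membered aromatic ring of carbon only for a five-membered aromatic ring with a hetero atom, yet in this assay this gives a 1.2-fold lower number from compound 3 to compound 4 (0.07 log units; within the scatter) and stays inside the scatter. Set against 2-phenylethenyl, the same group gives a 1.1-fold higher number from compound 2 to compound 4 (0.03 log units; within the scatter) and also stays inside the scatter, so a change of ring size and ring atoms at the carbon next to the ring nitrogen has now joined the earlier swaps in producing no real difference. No supporting measurement explains why these groups give such similar numbers.

On these data alone, whether an amine, a carboxylic acid or a longer alkyl chain at this carbon would give a step beyond the scatter remains open. So does the effect of any change to the shared core.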